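Adding a tert-Butyl Group to the Benzyl Side Chain

This account rests on a few compounds, and the source may have more. Where it says the series, first, only, none or still open, it means among the compounds named here.

Compound 1 `CCCCCCCc1nc(N)n(CC(=O)Nc2ccccc2)c1-c1ccccc1Br`: 9200 nM
Compound 2 `Nc1nc(Cc2ccccc2)c(-c2ccccc2Br)n1CC(=O)Nc1ccccc1`: 5200 nM

Of the compounds shown here, two have been measured in a functional assay on A-375 cells (Homo sapiens) for antiproliferative activity, read by MTT assay, with a stated time of 48 h; a lower number here means a stronger inhibitor, a higher number a weaker inhibitor. Compound 1 gives 9200 nM and compound 2 gives 5200 nM. Compound 2 holds the lowest of the two numbers, yet the step of a 1.8-fold lower number from compound 1 to compound 2 (0.25 log units; within the scatter) is within the scatter, so the two compounds stand side by side rather than apart. Compound 3 `CC(C)(C)c1ccc(Cc2nc(N)n(CC(=O)Nc3ccccc3)c2-c2ccccc2Br)cc1` differs from compound 2 by tert-butyl in place of hydrogen on an aromatic carbon. For the measured compounds named here, no measured step touches the phenyl ring itself; the only known step, a 1.8-fold lower number from compound 1 to compound 2 (0.25 log units; within the scatter), exchanged the whole hexyl for phenyl and moved the number little. Nothing in these data points to a shift beyond the scatter, so the step of a 1.3-fold lower number from compound 2 to compound 3 (0.11 log units; within the scatter) is expected to stay small, within the usual spread. Compound 3 is therefore estimated at 4000 nM, with a range from 1500 nM to 12000 nM.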

Compound 3, half-maximal inhibitory concentration: 2800 nM
Compound 3: middle estimate off by 1.4-fold (0.15 log units), on the high side; low and high end bracket the measured number.
By their numbers in this assay, from the lowest: compounds 3, 2 and 1 (each within the scatter of the next, the first and the last beyond it).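

Placed on an aromatic carbon para to a large group, tert-butyl in place of hydrogen leaves the benzyl side chain's reading within the scatter in this assay, where the step is a 1.9-fold lower number from compound 2 to compound 3 (0.27 log units; within the scatter) and the two compounds cannot be told apart. Against the hexyl chain the picture differs: the step of a 3.3-fold lower number from compound 1 to compound 3 (0.52 log units; beyond the scatter) is modest but beyond the scatter, the first gap in this set to clear it, while compound 2 lies within the scatter of both neighbours. Nothing at hand explains either step.

The compounds shown leave open whether a methyl group, an amine or a carboxylic acid on that same aromatic carbon would read any differently from compound 2. They also leave open whether tert-butyl on another carbon of that ring would give a similar number.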